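The source may hold more compounds than are shown below. What is called first, only, known or untested is meant among the compounds shown, and "the series" means these compounds.

The series shares one core and varies the aryl group on an oxygen. In a functional assay on Jurkat cells (Homo sapiens) (on this read-out higher numbers stand for weaker inhibition and lower numbers for stronger inhibition), compound 1 (`CC(C)[C@H](NC(=O)COc1cccc2ccccc12)C(=O)N[C@@H](CC(=O)O)C(=O)COc1ccc(C(F)(F)F)cc1`) gives > 100000 nM as a limit of the assay and not a number. Compound 2 (`CC(C)[C@H](NC(=O)COc1cccc2ccccc12)C(=O)N[C@@H](CC(=O)O)C(=O)COc1ccccc1F`) gives > 100000 nM as a limit too. Compound 3 (`CC(C)[C@H](NC(=O)COc1cccc2ccccc12)C(=O)N[C@@H](CC(=O)O)C(=O)COc1cc(F)ccc1F`) likewise gives > 100000 nM as a limit. Compound 3 thus stands with the other two, and the whole record is the limit of > 100000 nM in this assay, at which 3 of the 3 values shown sit, with no readable number among them.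

Compound 4 (`CC(C)[C@H](NC(=O)COc1cccc2ccccc12)C(=O)N[C@@H](CC(=O)O)C(=O)COc1cc(F)cc(F)c1F`) differs from compound 3 by a single change (fluoro in place of hydrogen on an aromatic carbon), which turns 2,5-difluorophenyl into 2,3,5-trifluorophenyl. Within the data shown here, the nearest precedent is the same replacement of hydrogen by fluoro, seen as a step that the two limits leave unreadable from compound 2 to compound 3 and offering no size. The wider aryl swaps (a step that the two limits leave unreadable from compound 1 to compound 2) and (a step that the two limits leave unreadable from compound 1 to compound 3) offer none either. Among the measured compounds shown here, with no measured step to scale from, no shift beyond the scatter is expected in this assay, and compound 4 is expected most likely to be reported at the same limit. The estimate amounts to an expected step (a number no higher from compound 3 to compound 4 (the limit leaves the size open)). For compound 4 the estimated value is 100000 nM (expected range 30000 nM to 300000 nM).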

Compound 4, half-maximal inhibitory concentration: 30000 nM
For compound 4 the middle estimate is 3.3-fold (0.52 log units) above the measured one; low and high end bracket the measured number.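

Among these compounds, the new fluoro, ortho to a fluoro group and meta to a large group, brings the first readable number in this assay, with an at least 3.3-fold lower number from compound 3 to compound 4 (0.52 log units; beyond the scatter), whereas the steps among compound 1, compound 2 and compound 3 cannot be read. The swaps to 2,3,5-trifluorophenyl read the same way, with an at least 3.3-fold lower number from compound 2 to compound 4 (0.52 log units; beyond the scatter) starting from 2-fluorophenyl and an at least 3.3-fold lower number from compound 1 to compound 4 (0.52 log units; beyond the scatter) starting from 4-(trifluoromethyl)phenyl. This aromatic carbon is therefore a place where a single fluoro can move the read-out beyond the scatter, although each step gives only a minimum size and compound 4 remains the only compound off the limit: the limit of > 100000 nM in this assay, at which 3 of the 4 values shown sit.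

The compounds shown leave open whether the fluoro at this position acts alone or needs the other two fluoro groups of 2,3,5-trifluorophenyl, and whether chloro, methoxy or a nitrile on the same aromatic carbon would give a lower number or a higher one. From the compounds shown here alone, they also leave open how far the true values of compound 1, compound 2 and compound 3 lie from the limit, so the full size of each step stays unknown.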